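The compounds below may be only part of what the source reports. "The series", "measured", "known", "first", "only" and "open" are said of these compounds alone.

Of the compounds shown here, three built on one shared core have been tested in a functional assay on the whole organism (strain albino) for inhibition, with Rattus norvegicus as the target, read by paw edema, with stated times of 30 min and 4 h, at a dose of 0.28 mmol/kg by the oral route; on this read-out higher numbers stand for more inhibition at the one dose given (going by the name of the read-out) and lower numbers for less inhibition. Compound 1 `CCn1c(SCC(=O)Nc2ccc(C(C)=O)cc2)nnc1-c1ccc(OC)c(OC)c1` gives 69% in this assay. Compound 2 `C=CCn1c(SCC(=O)Nc2ccc(C(C)=O)cc2)nnc1-c1ccc(OC)c(OC)c1` gives 70% in this assay, and compound 3 `C=CCn1c(SCC(=O)Nc2ccc(/C(C)=N/O)cc2)nnc1-c1ccc(OC)c(OC)c1` gives 79% in this assay. Among these three numbers compound 2 stands second highest; its nearest neighbour is compound 1, and the step of a number 1 percentage points higher from compound 1 to compound 2 (within the scatter) lies within the scatter, as does the step of a number 9 percentage points higher from compound 2 to compound 3 (within the scatter).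

Compound 4 `C=CCn1c(SCC(=O)Nc2ccc(C(C)=O)cc2)nnc1-c1ccc(OC)cc1` has not yet been measured in this assay. It differs from compound 2 by hydrogen in place of methoxy on an aromatic carbon. Neither measured step touches the 3,4-dimethoxyphenyl group: one exchanges vinyl for methyl on a saturated chain carbon bound to an aromatic nitrogen, the other exchanges a group of 4 heavy atoms for a group of 3 heavy atoms on an aromatic carbon, and both were within the scatter. Within the data shown here, no measured pair speaks to removing a methoxy from this ring. With nothing bearing directly on the change, and both known steps small, a step of a number 5 percentage points lower from compound 2 to compound 4 (within the scatter) in this assay is expected, which is none beyond the scatter. For compound 4 in this assay the estimate is 65%, with a range from 50% to 78%.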

Compound 4, a percentage reported as inhibition, in the whole organism at one dose (the size of the read-out at that dose, not a potency): 68%
Compound 4: middle estimate off by 3 percentage points, on the low side; measured number inside the range.
By their numbers in this assay, from the lowest: compounds 4, 1, 2 and 3 (each within the scatter of the next, the first and the last beyond it).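

Going from 3,4-dimethoxyphenyl to 4-methoxyphenyl, with hydrogen in place of methoxy, gives a number 2 percentage points lower from compound 2 to compound 4 (within the scatter) in this assay, the first reading of any change on this ring. The earlier steps shown here altered only the vinyl-bearing chain on the aromatic nitrogen and the group on the other aromatic ring, so they left the role of this methoxy unknown; now it is clear that the read-out at this one dose does not depend on keeping the methoxy that sits ortho to the remaining methoxy group. No measured information on the compounds accounts for this result or tells what the methoxy does in the animal.

All the compounds shown still carry a methoxy on this ring, so it remains open whether the read-out would hold with an unsubstituted phenyl, or with a hydroxy group, a chlorine or a longer ether chain at these places. On these data alone, it is also open whether removing this methoxy would give the same small step in the oxime-bearing compound 3, and the single dose says nothing about potency.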